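A few compounds are considered here, and "the series" means these few. Any claim that something is new, unique, unknown or untested is made for them only; others in the source may bear on it.

The measured compounds:
- compound 1, `COc1cc(/C=N/NC(=O)CCc2nc3ccccc3c(=O)[nH]2)cc(OC)c1O`; in a physicochemical assay, read by spectrophotometry, with a stated time of 30 min (on this read-out higher numbers stand for weaker inhibition and lower numbers for stronger inhibition), compound 1 gives 126000000 nM 
- compound 2, `COc1cc(/C=N/NC(=O)CCc2nc3ccccc3c(=O)[nH]2)ccc1O`; compound 2 gives 204000000 nM 
- compound 3, `O=C(CCc1nc2ccccc2c(=O)[nH]1)N/N=C/c1cc(O)c(O)c(O)c1`; compound 3 gives 81000000 nM 

Compound 3 has the lowest number of the three. Its gap to compound 1 is within the usual scatter, so these two cannot be told apart on the numbers shown, while against compound 2 the step is clearer: a 2.5-fold lower number from compound 2 to compound 3 (0.40 log units; beyond the scatter).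

Compound 4, `COc1cc(/C=N/NC(=O)CCc2nc3ccccc3c(=O)[nH]2)cc(O)c1O`, differs from compound 3 in one place: methyl in place of hydrogen on an oxygen on an aromatic ring. The change turns one hydroxy into methoxy, so the ring of compound 4 stands between the 3,4,5-trihydroxyphenyl of compound 3 and the 4-hydroxy-3-methoxyphenyl of compound 1. For the measured compounds named here, two steps bear on it. a 2.5-fold lower number from compound 2 to compound 3 (0.40 log units; beyond the scatter) describes the full swap between those two rings, and compound 4 undoes only part of it. a 1.6-fold higher number from compound 1 to compound 2 (0.21 log units; within the scatter) shows that adding or removing a methoxy group changed little. A small move toward a higher number, most likely within the scatter, is therefore expected: a 1.2-fold higher number from compound 3 to compound 4 (0.09 log units; within the scatter). Compound 4 is estimated at 100000000 nM, with a range from 50000000 nM to 200000000 nM.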

Compound 4, half-maximal inhibitory concentration: 104000000 nM
Compound 4: the middle estimate sits 1.0-fold (0.02 log units) below what was measured; the range from low to high includes it.
By their numbers in this assay, from the lowest: compounds 3, 4, 1 and 2 (each within the scatter of the next, the first and the last beyond it).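

Putting a methyl on this oxygen of the aromatic ring, which turns hydroxy into methoxy, gives a 1.3-fold higher number from compound 3 to compound 4 (0.11 log units; within the scatter) in this assay, so hydrogen and methyl cannot be told apart here. The same holds for the other two comparisons: removing the methyl from the other methoxy group gives a 1.2-fold lower number from compound 1 to compound 4 (0.08 log units; within the scatter), and hydroxy in place of hydrogen on an aromatic carbon gives a 2.0-fold lower number from compound 2 to compound 4 (0.29 log units; within the scatter). Compound 4 therefore splits the route from compound 2 to compound 3 into two steps that each lie within the scatter, even though the whole route gives a 2.5-fold lower number from compound 2 to compound 3 (0.40 log units; beyond the scatter), so neither change can be singled out as the one that matters.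

As far as these compounds go, whether an ethyl group on this oxygen, or an amine in place of this hydroxy, would give a step beyond the scatter remains open. No measured evidence here explains any of these numbers.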